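Swapping an Alkyne Chain for a Methanesulfonamido Phenyl

The compounds below may be only part of what the source reports. "The series", "measured", "known", "first", "only" and "open" are said of these compounds alone.

Compound 1, `COc1cc(C(O)(C(F)(F)F)C(F)(F)F)cnc1N1CCN(S(=O)(=O)c2ccc(N)nc2)CC1`, gives < 14 mL.min-1.g-1 in an ADME assay (liver) for metabolic stability, with Liver microsome (Homo sapiens) as the target, using microsomes and NADPH, with a stated time of 30 min, tested at 1 uM (on this read-out lower numbers stand for slow clearance and higher numbers for fast clearance), which is a limit of the assay rather than a number. Compound 2, `COCC#Cc1cc(C(O)(C(F)(F)F)C(F)(F)F)cnc1N1CCN(S(=O)(=O)c2ccc(N)nc2)CC1`, gives 15 mL.min-1.g-1 in this assay. Compound 3, `Nc1ccc(S(=O)(=O)N2CCN(c3ncc(C(O)(C(F)(F)F)C(F)(F)F)cc3C#CCCO)CC2)cn1`, gives < 14 mL.min-1.g-1 in this assay, again a limit rather than a number.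

Compound 2 therefore holds the only number shown; the two other values are limits, both sitting at the limit of < 14 mL.min-1.g-1 in this assay, at which 2 of the 3 values shown sit. The change to compound 4, `CS(=O)(=O)Nc1cccc(-c2cc(C(O)(C(F)(F)F)C(F)(F)F)cnc2N2CCN(S(=O)(=O)c3ccc(N)nc3)CC2)c1`, is this: 3-(methanesulfonamido)phenyl in place of 3-methoxyprop-1-yn-1-yl on an aromatic carbon.

Among the compounds with values here, two measured steps touch the same position. The step of an at least 1.0-fold higher number from compound 1 to compound 2 (0.02 log units; that floor lies within the scatter) and the step of an at least 1.0-fold lower number from compound 2 to compound 3 (0.02 log units; that floor lies within the scatter) both carry floors that lie within the usual scatter, so neither shows a movement in clearance that can be read. Within the data shown here, both, however, exchange small chain groups; none of the measured compounds carries an aromatic ring at this position, so the measured steps give no direct guide to the size of the present change.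

On that basis the step of a 1.1-fold higher number from compound 2 to compound 4 (0.05 log units; within the scatter) is expected to stay close to the scatter, with a wide range to allow for the unprecedented group. Compound 4 is estimated at 17 mL.min-1.g-1, between 7 mL.min-1.g-1 and 45 mL.min-1.g-1.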

Compound 4, intrinsic clearance in microsomes: 40 mL.min-1.g-1
The estimate for compound 4 lay 2.4-fold (0.37 log units) below the measured number; the range from low to high includes it.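

In this assay, within the data shown here, this position responds clearly for the first time once the 3-(methanesulfonamido)phenyl group sits on it, giving a 2.7-fold higher number from compound 2 to compound 4 (0.43 log units; beyond the scatter); the earlier steps among the small groups cannot be read, so they showed no such movement. Set against the methoxy and 4-hydroxybut-1-yn-1-yl groups, the same group points the same way, with an at least 2.8-fold higher number from compound 1 to compound 4 (0.45 log units; beyond the scatter) and an at least 2.8-fold higher number from compound 3 to compound 4 (0.45 log units; beyond the scatter), so all three groups without a ring sit on the lower-clearance side of compound 4. Those two steps give only a minimum size and not a true one, since compound 1 and compound 3 each carry a limit of the assay rather than a number: the limit of < 14 mL.min-1.g-1 in this assay, at which 2 of the 4 values shown sit.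

The change brings in the aromatic ring and the methanesulfonamido group together, so the compounds shown cannot tell which of the two goes with the higher clearance. A plain phenyl group, or a phenyl carrying an amine or a carboxylic acid in place of the methanesulfonamido group, would begin to separate the ring from what it carries.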